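Chloro to methylpiperazinyl on the shared core

A few compounds are considered here, and "the series" means these few. Any claim that something is new, unique, unknown or untested is made for them only; others in the source may bear on it.

Measured in a functional assay on Bel-7402 cells (Homo sapiens) for cytotoxicity, read by MTT assay, with a stated time of 48 h; on this read-out lower numbers stand for stronger inhibition and higher numbers for weaker inhibition:
- compound 1 `CCn1cc(-c2nc3ccccc3o2)c(=O)c2cc(F)c(Cl)cc21`: 28900 nM
- compound 2 `CCn1cc(-c2nc3ccccc3o2)c(=O)c2cc(F)c(N3CCNC(C)C3)c(F)c21`: 5700 nM

Compound 1 stands highest of the two at 28900 nM, and the lower number of compound 2 lies beyond the scatter. Compound 3 `CCn1cc(-c2nc3ccccc3o2)c(=O)c2cc(F)c(N3CCN(C)CC3)cc21` remains unmeasured. It has 4-methylpiperazin-1-yl in place of chloro on an aromatic carbon, ortho to a fluoro group: 4-methylpiperazin-1-yl in place of chloro on an aromatic carbon. For the measured compounds named here, no measured pair isolates this change. Compound 2, which also lacks chloro and bears a non-aromatic ring, gives 5700 nM, so a lower number is expected in this assay, with an estimated 3.6-fold lower number from compound 1 to compound 3 (0.56 log units; beyond the scatter) beyond the scatter. For compound 3 the estimate is 8000 nM, with an expected range of 2500 nM to 22000 nM.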

Compound 3, half-maximal inhibitory concentration: 2000 nM
For compound 3 the middle estimate is 4.0-fold (0.60 log units) above the measured one, outside the stated range (below it).
By their numbers in this assay, from the lowest: compound 3; then compound 2; then compound 1.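

In this assay the aromatic carbon ortho to a fluoro group accepts much more than a single chlorine: 4-methylpiperazin-1-yl in place of chloro gives a 14-fold lower number from compound 1 to compound 3 (1.16 log units; beyond the scatter) and is a large step. For the compounds shown here, this is the first change read in one place, and it shows that this position strongly affects the read-out. No data bear on the reason for the step. Still open, from the compounds shown here alone, is whether the full 4-methylpiperazin-1-yl group is needed at this carbon, or whether morpholine or a simple dimethylamino group would give a similar step.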